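The source may hold more compounds than are shown below. What is called first, only, known or untested is meant among the compounds shown, and "the series" means these compounds.

Measured compounds:
- Compound 1, `CNC(=N)Nc1nc(-c2ccc(OC)cc2)c(-c2ccc(OC)cc2)s1`, in a functional assay with Oryctolagus cuniculus as the target (a lower number here means a stronger inhibitor, a higher number a weaker inhibitor), compound 1 gives 62 nM.
- Compound 2, `COc1ccc(-c2nc(/N=C(\N)NC3CCCCC3)sc2-c2ccc(OC)cc2)cc1`. In this assay compound 2 gives > 1000 nM, which is a limit of the assay and not a number.

Going by the values given here, compound 1 is thus the only compound of the set with a number in this assay; the other entry is a limit (the limit of > 1000 nM in this assay, at which 1 of the 2 values shown sits). Compound 3, `COc1ccc(-c2nc(C(=O)N3CCCCC3)sc2-c2ccc(OC)cc2)cc1`, is not yet measured; it differs from compound 1 by a group of 8 heavy atoms (6 carbon, 1 nitrogen, 1 oxygen; one six-membered non-aromatic ring with 1 hetero atom) in place of a group of 5 heavy atoms (2 carbon, 3 nitrogen; no ring), on an aromatic carbon.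

Among the compounds with values here, the one measured step bearing on this change is an at least 16-fold higher number from compound 1 to compound 2 (1.20 log units; beyond the scatter), where a larger group carrying a six-membered non-aromatic ring replaced the same small group on the same aromatic carbon. Compound 3 again places a six-membered non-aromatic ring at that carbon, and it also gives up all three hydrogen-bond donors of the group that leaves. A large step toward a higher number is therefore expected, a 24-fold higher number from compound 1 to compound 3 (1.38 log units; beyond the scatter). Compound 3 is estimated at 1500 nM, in the range 300 nM to 8000 nM, with a real chance that only a limit is reported.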

Compound 3, half-maximal inhibitory concentration: > 1000 nM
Compound 3 was reported as a limit; the forecaster's own chance of this, stated with the estimate: 60%; the middle value does not contradict the limit.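

In this assay, replacing the group of 5 heavy atoms on this aromatic carbon with (piperidin-1-yl)carbonyl gives an at least 16-fold higher number from compound 1 to compound 3 (1.20 log units; beyond the scatter). The entering group has 0 hydrogen-bond donors, and this second ring-bearing group lands in the same place as the group of compound 2, so the loss is not tied to one particular replacement. Each of compound 2 and compound 3 is reported as a limit and not a number, and the step between them cannot be read: the limit of > 1000 nM in this assay, at which 2 of the 3 values shown sit.

The compounds shown do not separate the ring from the missing hydrogen-bond donors as the source of the loss. Also open, on these data alone, is whether a small, ring-free group at this carbon, such as an amine or an unsubstituted guanidine, stays close to compound 1 at 62 nM.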